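The source may hold more compounds than are shown below. What is called first, only, known or untested is meant among the compounds shown, and "the series" means these compounds.

Compound 1 is `Cc1ccc2c(NCc3ccc(NC(=O)C4CCN(Cc5ccc(Cl)cc5)CC4)cc3)nc(N(C)C)nc2c1`. In a functional assay on SV5A8 cells (Homo sapiens) for cytotoxicity (a lower number here means a stronger inhibitor, a higher number a weaker inhibitor), compound 1 gives > 3180 nM, a limit of the assay and not a number (the limit of > 3180 nM in this assay, at which 1 of the 3 values shown sits). Compound 2 is `Cc1ccc(CN2CCC(C(=O)Nc3ccc(CNc4nc(N(C)C)nc5cc(C)ccc45)cc3)CC2)cc1`; in this assay compound 2 gives > 4150 nM, again only a limit (the limit of > 4150 nM in this assay, at which 1 of the 3 values shown sits). Compound 3 is `Cc1ccc2c(NCc3ccc(NC(=O)C4CCN(Cc5ncc[nH]5)CC4)cc3)nc(N(C)C)nc2c1`; in this assay compound 3 gives > 20000 nM, likewise a limit (the limit of > 20000 nM in this assay, at which 1 of the 3 values shown sits). The three steps among them, a step that the two limits leave unreadable from compound 1 to compound 2, a step that the two limits leave unreadable from compound 1 to compound 3 and a step that the two limits leave unreadable from compound 2 to compound 3, therefore carry no readable size: exchanging the chlorophenyl, methylphenyl or imidazolyl groups on the saturated chain carbon bound to the ring amine nitrogen leaves every value at a limit.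

Compound 4 is `CCCCN1CCC(C(=O)Nc2ccc(CNc3nc(N(C)C)nc4cc(C)ccc34)cc2)CC1`. It differs from compound 1 by propyl in place of 4-chlorophenyl on a saturated chain carbon bound to an amine nitrogen in a ring. The measured steps that bear on this position are all unreadable, so no direction or size can be derived from them. The step from compound 1 to compound 4 in this assay is expected as a step that the limit leaves unreadable from compound 1 to compound 4, with compound 4 most probably returning only a limit again. Compound 4 is estimated at 10000 nM, ranging from 3000 nM to 40000 nM.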

Compound 4, half-maximal inhibitory concentration: > 10500 nM
Compound 4: a limit, no number (the forecaster's own chance of this, stated with the estimate: 75%); at least 1.0-fold (0.02 log units) between middle value and limit.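

In this assay compound 4 gives > 10500 nM, again a limit and not a number, so its steps from compound 1, compound 2 and compound 3 cannot be read. The compounds shown leave open how far apart these four compounds actually lie in this assay.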